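Cytotoxicity notes on the series: compound 4 before measurement

A few compounds are considered here, and "the series" means these few. Any claim that something is new, unique, unknown or untested is made for them only; others in the source may bear on it.

Measured so far:
compound 1 `Nc1nc(OCC(F)(F)F)c2ncn(/C=C3/CC3(CO)CO)c2n1`, > 20000 nM in an ADME assay on Akata cells (Homo sapiens) for cytotoxicity, with a stated time of 7 days (on this read-out lower numbers stand for higher toxicity in this test and higher numbers for lower toxicity in this test), a limit of the assay rather than a number.
compound 2 `Nc1nc(OCc2ccccc2)c2ncn(/C=C3/CC3(CO)CO)c2n1`, > 20000 nM in this assay, again a limit.
compound 3 `CC(C)Nc1nc(N)nc2c1ncn2/C=C1/CC1(CO)CO`, > 24000 nM in this assay, again a limit.

Compound 1 therefore stands at a limit only, as do the other two values shown, two sitting at the limit of > 20000 nM in this assay, at which 2 of the 3 values shown sit, and one at the limit of > 24000 nM in this assay, at which 1 of the 3 values shown sits. Compound 4 `CCCOc1nc(N)nc2c1ncn2/C=C1/CC1(CO)CO` differs from compound 1 in one place: ethyl in place of trifluoromethyl on a saturated chain carbon bound to an oxygen on an aromatic ring. Going by the values given here, the steps that bear on the same position, a step that the two limits leave unreadable from compound 1 to compound 2 and a step that the two limits leave unreadable from compound 1 to compound 3, are both of unreadable size, so no direction and no size beyond the scatter can be read from them. Compound 4 is therefore expected to sit at a limit as well, with an estimated step that the limit leaves unreadable from compound 1 to compound 4. The estimate for compound 4 is 30000 nM, with a range from 15000 nM to 80000 nM.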

Compound 4, half-maximal cytotoxic concentration: > 20000 nM
Compound 4 ended at the assay's limit; the forecaster's own chance of this, stated with the estimate: 85%; the middle value is on the limit's open side.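

Going by these compounds alone, compound 1, compound 2, compound 3 and compound 4 all stand at limits in this assay, so no step to compound 4 can be read. The compounds shown leave open where any true value lies beyond its limit.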